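Halogen exchange on the benzylidene arm of compound 1

The source may report more compounds than this note shows. Statements on the series, on what has been measured and on what is new or still open speak of the compounds shown alone.

Among the compounds with values here, compound 1 `C=CCn1c(=O)/c(=C\c2ccccc2Cl)[nH]c(=O)/c1=C\c1ccccc1OC` in a functional assay on HL-60 cells (Homo sapiens) for cytotoxicity, read by CCK-8 assay, with a stated time of 72 h (on this read-out higher numbers stand for weaker inhibition and lower numbers for stronger inhibition), gives 4200 nM, the highest number among the three measured members. Compound 2 `COc1ccccc1/C=c1\c(=O)[nH]/c(=C/c2cccc(Cl)c2Cl)c(=O)n1C` gives 200 nM and compound 3 `COc1ccccc1/C=c1\c(=O)[nH]/c(=C/c2ccccc2Cl)c(=O)n1C` gives 200 nM. The step of a 21-fold lower number from compound 1 to compound 3 (1.32 log units; beyond the scatter) is large, so the substituent on the aromatic nitrogen separates compound 1 from the other two; the step of no change at the digits printed from compound 2 to compound 3 (within the scatter) is within the scatter, so removal of one chloro from an aromatic carbon is not felt on this read-out.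

Compound 4 `C=CCn1c(=O)/c(=C\c2ccccc2F)[nH]c(=O)/c1=C\c1ccccc1OC` keeps the vinyl-bearing chain of compound 1 and differs from it at a single point: fluoro in place of chloro on an aromatic carbon. Within the data shown here, no measured pair exchanges chloro for fluoro directly. Among the measured compounds shown here, the only measured step touching a halogen on an aromatic carbon, no change at the digits printed from compound 2 to compound 3 (within the scatter), stayed within the scatter, and that is the nearest guide available. The expectation is therefore a 1.1-fold higher number from compound 1 to compound 4 (0.03 log units; within the scatter), with no step beyond the scatter in either direction. Compound 4 is estimated at 4500 nM in this assay, with a range from 1500 nM to 13000 nM.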

Compound 4, half-maximal inhibitory concentration: 18500 nM
Beside the measured number, compound 4's estimate is 4.1-fold (0.61 log units) below it, outside the stated range (above it).
By their numbers in this assay, from the lowest: compounds 2 and 3 (each within the scatter of the next); then compound 1; then compound 4.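

The 2-chlorophenyl to 2-fluorophenyl exchange is felt in this assay, with a 4.4-fold higher number from compound 1 to compound 4 (0.64 log units; beyond the scatter) as a modest step beyond the scatter, so this halogen position is not silent on the read-out. The earlier halogen step, no change at the digits printed from compound 2 to compound 3 (within the scatter), removed a different chloro and stayed within the scatter, so that result does not carry over to this position. No measurement on hand explains the loss on going from chloro to fluoro.

Going by these compounds, whether the same exchange has a comparable effect with the methyl group on the aromatic nitrogen, as in compound 3, remains open. Also open, on these data alone, is how bromo, trifluoromethyl or methoxy at this position would read against chloro and fluoro, and so whether the trend follows halogen size or is specific to this pair.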